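A few compounds are considered here, and "the series" means these few. Any claim that something is new, unique, unknown or untested is made for them only; others in the source may bear on it.

Measured compounds in the series:
- compound 1 `C=CCn1c(=O)/c(=C\c2cccc(F)c2)[nH]c(=O)/c1=C\c1ccccc1OC` — 5600 nM
- compound 2 `C=CCn1c(=O)/c(=C\c2ccc(Cl)c(Cl)c2)[nH]c(=O)/c1=C\c1ccccc1OC` — "not active" (no number reported)

In a functional assay on BGC-823 cells (Homo sapiens) for cytotoxicity, read by CCK-8 assay, with a stated time of 72 h (on this read-out higher numbers stand for weaker inhibition and lower numbers for stronger inhibition), compound 1 gives 5600 nM. In this assay, among the compounds with values here, compound 2 is recorded only as "not active" (no number reported), so no number is available for it and no numeric step from it can be drawn. On the numbers shown, compound 2 therefore stands apart from compound 1 only in that compound 1 has a measured value and compound 2 does not.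

Compound 3 `C=CCn1c(=O)/c(=C\c2cc(Br)ccc2F)[nH]c(=O)/c1=C\c1ccccc1OC` differs from compound 2 in one place: 5-bromo-2-fluorophenyl in place of 3,4-dichlorophenyl on a double-bonded chain carbon bound to an aromatic carbon. Since compound 2 has no number, the size and direction of the step from compound 2 to compound 3 in this assay cannot be predicted from a measured pair; the available anchor is compound 1 with 5600 nM, and compound 3 is expected to land near that weak range or beyond it. Compound 3 is estimated at 15000 nM, within 4000 nM to 60000 nM.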

Compound 3, half-maximal inhibitory concentration: "not active" (no number reported)
The entry for compound 3 holds no number; no gap can be computed for the estimate.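

In this assay, within the data shown here, compound 2 and compound 3 are both recorded only as not active, so no step between them can be read. No measured evidence bears on this result. The compounds shown leave open how far compound 2 and compound 3 lie from compound 1 at 5600 nM.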